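The source may report more compounds than this note shows. Statements on the series, on what has been measured and on what is new or still open speak of the compounds shown alone.

Measured compounds:
Compound 1 `CCOC(=O)c1c(-c2c(Cl)c3cc(C)ccc3oc2=O)nn(-c2ccccc2)c1C(=O)OCC` gives 50000 nM in a functional assay on DU-145 cells (Homo sapiens) for cytotoxicity, read by MTT assay, with a stated time of 48 h; a lower number here means a stronger inhibitor, a higher number a weaker inhibitor.
Compound 2 `CCOC(=O)c1c(-c2c(Cl)c3cc(C)ccc3oc2=O)nn(-c2cccc(C)c2)c1C(=O)OCC` gives 103000 nM in this assay.
Compound 3 `CCOC(=O)c1c(-c2cc3cc(OC)ccc3oc2=O)nn(-c2ccccc2)c1C(=O)OCC` gives 27000 nM in this assay.

Compound 1 and compound 2 share one core and differ only by methyl in place of hydrogen on an aromatic carbon. In this assay that change produced a 2.1-fold higher number from compound 1 to compound 2 (0.31 log units; beyond the scatter), a modest loss of potency. Compound 3 carries a different core; the difference between the two cores is not broken down here. Compound 3 has the lowest number of the three, but its gap to compound 1 lies within the usual scatter, so the two cannot be ordered, whereas its gap to compound 2 lies beyond it.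

Compound 4 `CCOC(=O)c1c(-c2cc3cc(OC)ccc3oc2=O)nn(-c2cccc(C)c2)c1C(=O)OCC` has not yet been measured in this assay. Within the data shown here, it differs from compound 3 by methyl in place of hydrogen on an aromatic carbon, the same change, at the same kind of place, as the one from compound 1 to compound 2. Among the measured compounds shown here, the step from compound 3 to compound 4 is therefore expected to be a 2.1-fold higher number from compound 3 to compound 4 (0.32 log units; beyond the scatter), because the one earlier instance of this change gave a 2.1-fold higher number from compound 1 to compound 2 (0.31 log units; beyond the scatter). For the measured compounds named here, with only a single precedent, the expectation is held loosely. Compound 4 is expected to give 57000 nM, with a likely range from 27000 nM to 120000 nM.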

Compound 4, half-maximal inhibitory concentration: 31000 nM
Compound 4: the middle estimate sits 1.8-fold (0.26 log units) above what was measured; measured number inside the range.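

In this assay, the change from phenyl to 3-methylphenyl on the second core gave a 1.1-fold higher number from compound 3 to compound 4 (0.06 log units; within the scatter), so no effect of the methyl can be read on that core. Set beside the earlier step, the two results cannot be told apart: the same change on two cores in this assay, a 2.1-fold higher number (0.31 log units; beyond the scatter) from compound 1 to compound 2 and a 1.1-fold higher number (0.06 log units; within the scatter) from compound 3 to compound 4, 1.8-fold (0.25 log units) apart, within the scatter of two such steps

This agreement is weak support for carrying the change across, since one step lies beyond the scatter and the other within it; the two steps show neither that the change transfers unaltered nor that the core modifies it, and they give no reliable size for it on a further core.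

The compounds shown leave open how the aromatic ring would respond to a group other than methyl in that place, such as a fluorine, an amine or a carboxylic acid. They also leave open which of the differences between the two cores bears on the numbers, and whether an ethyl ester could be replaced by an amide.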